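Trimming a Saturated Ring at the Far End

This account rests on a few compounds, and the source may have more. Where it says the series, first, only, none or still open, it means among the compounds named here.

Compound 2 `COCCN[C@H]1CC[C@H](Nc2cc(-c3csc(NCC4CCOCC4)n3)c(Cl)cn2)CC1` gives 170 nM in a functional assay on MV4-11 cells (Homo sapiens) for antiproliferative activity, read by CellTiter-Glo, with a stated time of 72 h (on this read-out lower numbers stand for stronger inhibition of growth and higher numbers for weaker inhibition of growth), the lowest number among the three measured compounds. Compound 3 `COC[C@H](C)N[C@H]1CC[C@H](Nc2cc(-c3csc(NCC4CCOCC4)n3)c(Cl)cn2)CC1` gives 440 nM and compound 1 `CC(=O)N[C@H]1CC[C@H](Nc2cc(-c3csc(NCC4CCOCC4)n3)c(Cl)cn2)CC1` gives 3600 nM. The steps seen so far all concern the other amine nitrogen: a 21-fold lower number from compound 1 to compound 2 (1.33 log units; beyond the scatter), an 8.2-fold lower number from compound 1 to compound 3 (0.91 log units; beyond the scatter) and a 2.6-fold higher number from compound 2 to compound 3 (0.41 log units; beyond the scatter). Compound 4 `COCCN[C@H]1CC[C@H](Nc2cc(-c3csc(NCC4CCOC4)n3)c(Cl)cn2)CC1` differs from compound 2 elsewhere: oxolan-3-yl in place of oxan-4-yl on a saturated chain carbon bound to a nitrogen on an aromatic ring, a six-membered ring giving way to a five-membered one. Among the measured compounds shown here, no measured pair touches this part of the molecule, so the expectation rests on the shared core and the unchanged 2-methoxyethyl group alone, and the expected step is none beyond the scatter, a 1.2-fold higher number from compound 2 to compound 4 (0.07 log units; within the scatter). Compound 4 is therefore estimated at 200 nM, within a range of 80 nM to 500 nM.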

Compound 4, concentration for 50% growth inhibition: 493 nM
Beside the measured number, compound 4's estimate is 2.5-fold (0.39 log units) below it, within the range that was stated.
By their numbers in this assay, from the lowest: compound 2; then compounds 3 and 4 (each within the scatter of the next); then compound 1.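

The part of the molecule far from the other amine nitrogen is not indifferent to change: in this assay, oxolan-3-yl in place of oxan-4-yl gives a 2.9-fold higher number from compound 2 to compound 4 (0.46 log units; beyond the scatter), a step beyond the scatter. Losing a single ring carbon at this place is thus enough to weaken growth inhibition, though both groups count the same hydrogen-bond donors and acceptors. Nothing measured here explains the step.

The compounds shown leave open how cyclohexyl, with no ring oxygen, or the smaller oxetan-3-yl would fare at this place. They also leave open whether the step would recur with acetyl on the other amine nitrogen.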